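Urea-Linked Compounds: Swapping Hydroxy for Amino

The source may hold more compounds than are shown below. What is called first, only, known or untested is meant among the compounds shown, and "the series" means these compounds.

Three compounds sharing one core have been examined in a physicochemical assay for solubility, at pH 7.4; on this read-out higher numbers stand for higher solubility and lower numbers for lower solubility. Compound 1 `Cc1cc(NC(=O)Nc2ccccc2N)c2ccccc2n1` gives 51800 nM. Compound 2 `Cc1cc(NC(=O)Nc2cccc(F)c2)c2ccccc2n1` gives 100 nM, and compound 3 `Cc1cc(NC(=O)Nc2ccc(O)cc2)c2ccccc2n1` gives 100 nM. Compound 3 therefore stands level with compound 2 at the digits shown, the two of them together being the lowest of the three numbers, while compound 1 sits far higher: a 520-fold lower number from compound 1 to compound 3 (2.71 log units; beyond the scatter), and no change at the digits printed from compound 2 to compound 3 (within the scatter).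

The next compound, compound 4 `Cc1cc(NC(=O)Nc2ccc(N)cc2)c2ccccc2n1`, differs from compound 3 in one place: amino in place of hydroxy on an aromatic carbon. Among the compounds with values here, no measured pair shows this exact swap at this place. The step from compound 1 to compound 3 does involve an amino group and a hydroxy group, but their places on the ring differ too, so it gives only a loose hint that an amino group may go with a higher number. The step from compound 2 to compound 3 shows that a change of group at this ring can also leave the number unchanged. A modest rise in this assay is expected for compound 4, a 4.0-fold higher number from compound 3 to compound 4 (0.60 log units; beyond the scatter), though a result within the scatter would not surprise. The estimate for compound 4 is 400 nM, within a range from 100 nM to 3000 nM.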

Compound 4, solubility: 18500 nM
Compound 4: middle estimate off by 46-fold (1.67 log units), on the low side, outside the stated range (above it).
By their numbers in this assay, from the lowest: compounds 2 and 3 (each within the scatter of the next); then compound 4; then compound 1.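

At this place, para to a large group, the change from hydroxy to amino is far from neutral in this assay: a 190-fold higher number from compound 3 to compound 4 (2.27 log units; beyond the scatter), even though the two groups have matching counts of hydrogen-bond donors and acceptors. The comparison with the 3-fluorophenyl compound gives a similar gap, a 190-fold higher number from compound 2 to compound 4 (2.27 log units; beyond the scatter), so the flat step between compound 2 and compound 3 did not mean that changes on this ring leave the number unmoved. Moving the amino group costs far less, a 2.8-fold lower number from compound 1 to compound 4 (0.45 log units; beyond the scatter), and across these four compounds the two aminophenyl compounds stand at the top, with none going against this.

No supporting measurement explains the size of this jump. From the compounds shown here alone, what a dimethylamino or a methoxy group would give at this place remains open.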